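The compounds below may be only part of what the source reports. "The series", "measured", "known", "first", "only" and "open" are said of these compounds alone.

Compound 3 `O=C(c1ccc(OCCCN2CC[C@H](NS(=O)(=O)c3ccc(Br)cc3)C2)cc1)C1CC1` stands with the lowest number of the three in an assay on isolated protein for binding affinity to histamine H2 receptor (Homo sapiens) (a lower number here means a stronger inhibitor, a higher number a weaker inhibitor), giving 290 nM, while compound 1 `Cc1ccc(S(=O)(=O)N[C@H]2CCN(CCCOc3ccc(C(=O)C4CC4)cc3)C2)cc1` gives 380 nM and compound 2 `O=C(c1ccc(OCCCN2CC[C@H](NS(=O)(=O)c3cccc(F)c3)C2)cc1)C1CC1` gives 1600 nM. The step of a 1.3-fold lower number from compound 1 to compound 3 (0.12 log units; within the scatter) and the step of a 5.5-fold lower number from compound 2 to compound 3 (0.74 log units; beyond the scatter) are the measured changes on this sulfonyl-bound ring. Compound 4 `O=C(c1ccc(OCCCN2CC[C@H](NS(=O)(=O)c3ccc(F)cc3)C2)cc1)C1CC1` differs from compound 3 by fluoro in place of bromo on an aromatic carbon. Among the compounds with values here, no measured step swaps bromo for fluoro at the same place, so the bearing steps are indirect: a 1.3-fold lower number from compound 1 to compound 3 (0.12 log units; within the scatter) shows a para swap of small groups leaving the number unmoved, whereas a 5.5-fold lower number from compound 2 to compound 3 (0.74 log units; beyond the scatter) shows a fluorophenyl costing affinity. Compound 4 is therefore expected to give 600 nM, in a range from 250 nM to 1500 nM. For compound 4 the expected step is a 2.1-fold higher number from compound 3 to compound 4 (0.32 log units; beyond the scatter).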

Compound 4, inhibition constant: 500 nM
Compound 4: the middle estimate sits 1.2-fold (0.08 log units) above what was measured; the measured number falls inside the stated range.
By their numbers in this assay, from the lowest: compounds 3, 1 and 4 (each within the scatter of the next); then compound 2.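

In this assay the step for fluoro in place of bromo is a 1.7-fold higher number from compound 3 to compound 4 (0.24 log units; within the scatter), and the step for fluoro in place of methyl is a 1.3-fold higher number from compound 1 to compound 4 (0.12 log units; within the scatter), leaving these three groups on this aromatic carbon, para to a large group, unresolved. Moving the fluoro gives the first direct reading of placement with the halogen held constant: 4-fluorophenyl in place of 3-fluorophenyl is a 3.2-fold lower number from compound 2 to compound 4 (0.51 log units; beyond the scatter). Nothing at hand gives a reason for this gap. Still open, going by these compounds, is whether a methoxy, an amine or a carboxylic acid at this place would keep the number, and whether 3-bromophenyl would behave like the 3-fluorophenyl of compound 2.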